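Macrocycle series: acid cap against hydroxamate caps

This account rests on a few compounds, and the source may have more. Where it says the series, first, only, none or still open, it means among the compounds named here.

Measured so far in an assay on Sf9 cells for inhibition of protein deacetylase HDAC6 (Homo sapiens), read by fluorescence, with a stated time of 2 h; on this read-out higher numbers stand for weaker inhibition and lower numbers for stronger inhibition:
compound 1 `O=C(O)CCCCCOc1ccc2cc1COC/C=C/COCc1cccc(c1)-c1ccnc(n1)N2` gives 45000 nM
compound 2 `O=C(NO)c1ccc(OCCOc2ccc3cc2COC/C=C/COCc2cccc(c2)-c2ccnc(n2)N3)cc1` gives 66 nM

Compound 2 stands lowest of the two numbers in this assay. Among the measured compounds shown here, the only measured step, a 680-fold lower number from compound 1 to compound 2 (2.83 log units; beyond the scatter), went with a hydroxycarbamoyl group arriving in place of a carboxylic acid. Compound 3 `O=C(CCCCCOc1ccc2cc1COC/C=C/COCc1cccc(c1)-c1ccnc(n1)N2)NO` keeps a hydroxycarbamoyl group; the change is 3-(hydroxycarbamoyl)propyl in place of 4-(hydroxycarbamoyl)phenoxy on a saturated chain carbon, two bonds along the chain from an oxygen on an aromatic ring. For the measured compounds named here, no measured step addresses this part of the chain, so the expectation rests on the hydroxycarbamoyl group being retained. For compound 3 the estimated value is 300 nM, in the range 60 nM to 1500 nM. This estimate means a step of a 4.5-fold higher number from compound 2 to compound 3 (0.66 log units; beyond the scatter) is expected.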

Compound 3, half-maximal inhibitory concentration: 28 nM
For compound 3 the middle estimate is 11-fold (1.03 log units) above the measured one; measured number below the stated range.
By their numbers in this assay, from the lowest: compound 3; then compound 2; then compound 1.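

With the chain held constant, hydroxyamino in place of hydroxy on a carbonyl carbon gives a 1600-fold lower number from compound 1 to compound 3 (3.21 log units; beyond the scatter) and so separates this change from the swap of chain that also came with the earlier step. The benzene ring of 4-(hydroxycarbamoyl)phenoxy is not required at this position, since 3-(hydroxycarbamoyl)propyl in its place gives a 2.4-fold lower number from compound 2 to compound 3 (0.37 log units; beyond the scatter) beyond the scatter. No evidence is available to explain either step.

Still open, going by these compounds, is how a shorter or longer saturated chain ending in hydroxycarbamoyl would read. Also open, on these data alone, is whether a thiol or a 2-aminobenzamide could replace the hydroxycarbamoyl group.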